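Compound 3: One Group Changed, Starting from a Limit

The source may report more compounds than this note shows. Statements on the series, on what has been measured and on what is new or still open speak of the compounds shown alone.

For the measured compounds named here, in a functional assay on MDA-MB-231 cells (Homo sapiens) for antiproliferative activity, read by MTT assay, with a stated time of 24 h (on this read-out higher numbers stand for weaker inhibition and lower numbers for stronger inhibition), compound 1 (`O=C(O)CC(NC(=O)c1ccc(Cl)cc1Cl)c1ccccc1`) gives 67200 nM, the only true number so far.

Compound 2 (`COc1ccc(C(=O)NC(CC(=O)O)c2ccc(Cl)cc2Cl)cc1`) reads > 100000 nM in this assay, and this is a limit of the assay, not a number.

Compound 3 (`O=C(O)CC(NC(=O)c1ccc(Cl)cc1Cl)c1ccc(Cl)cc1Cl`) has not yet been measured. It differs from compound 2 in one place, where 2,4-dichlorophenyl takes the place of 4-methoxyphenyl on a carbonyl carbon: 2,4-dichlorophenyl in place of 4-methoxyphenyl on a carbonyl carbon.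

Going by the values given here, no measured pair shows what this swap does, so the size of the step is a judgement. The same 2,4-dichlorophenyl sits on the carbonyl carbon of compound 1, which gives 67200 nM, so a modest move towards stronger inhibition is expected in this assay. The result could still stop at the limit of the assay.

The expected step is an at least 2.0-fold lower number from compound 2 to compound 3 (0.30 log units; that floor lies within the scatter).

For compound 3 the estimated value is 50000 nM, with an expected range from 20000 nM to 100000 nM.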

Compound 3, half-maximal inhibitory concentration: 49200 nM
For compound 3 the middle estimate is 1.0-fold (0.01 log units) above the measured one; low and high end bracket the measured number.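

Going by these compounds, on the carbonyl carbon, 2,4-dichlorophenyl in place of 4-methoxyphenyl gives an at least 2.0-fold lower number from compound 2 to compound 3 (0.30 log units; that floor lies within the scatter), so in this assay this swap leads from a limit to a true number, although the real size of the step stays unknown. Compound 2 reads > 100000 nM, which is a limit and not a number, and the step rests on that limit: the limit of > 100000 nM in this assay, at which 1 of the 3 values shown sits. On the saturated chain carbon bound to an amide-type nitrogen and a saturated chain carbon, 2,4-dichlorophenyl in place of phenyl gives a 1.4-fold lower number from compound 1 to compound 3 (0.14 log units; within the scatter), so this second change does not separate the two compounds in this assay.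

The compounds shown leave open whether another group on the carbonyl carbon, such as 4-aminophenyl or cyclohexyl, would give a number clearly lower than the one for compound 3. They also leave open what 4-methoxyphenyl does on the saturated chain carbon when phenyl stands there instead of 2,4-dichlorophenyl, and what a longer chain carrying the carboxylic acid would do to the read-out.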